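This account rests on a few compounds, and the source may have more. Where it says the series, first, only, none or still open, it means among the compounds named here.

Compound 1 `Cc1cccc(C(=O)N(C(=S)OCCN2C(=O)c3ccccc3C2=O)c2ccc(Cl)cc2)c1` was tested in an ADME assay on MT4 cells (Homo sapiens) for cytotoxicity, read by MTT assay (on this read-out higher numbers stand for lower toxicity in this test and lower numbers for higher toxicity in this test), where compound 1 gives 58000 nM. Compound 2 `O=C1c2ccccc2C(=O)N1CCOC(=S)N(C(=O)c1cccc([N+](=O)[O-])c1)c1ccc(Cl)cc1` differs from compound 1 by the change (nitro in place of methyl on an aromatic carbon), and in this assay compound 2 gives 18000 nM. That change made a 3.2-fold lower number from compound 1 to compound 2 (0.51 log units; beyond the scatter), so compound 2 is the more toxic of the two in this test.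

Compound 3 `Cc1ccc(N(C(=O)c2ccccc2C)C(=S)OCCN2C(=O)c3ccccc3C2=O)cc1` rests on a different core; how that core differs from the core of compound 1 is not broken down here. In this assay compound 3 gives only a limit of the test, > 100000 nM, and not a number. Compound 3 thus stands at the limit of > 100000 nM in this assay, at which 1 of the 3 values shown sits.

Compound 4 `Cc1ccc(N(C(=O)c2ccccc2[N+](=O)[O-])C(=S)OCCN2C(=O)c3ccccc3C2=O)cc1` has not yet been measured and differs from compound 3 by nitro in place of methyl on an aromatic carbon. Among the measured compounds shown here, this is the same kind of change as the one from compound 1 to compound 2, but the place is not the same: in compound 2 the nitro sits meta to a large group, in compound 4 ortho to a large group.

For compound 4 a step of an at least 1.6-fold lower number from compound 3 to compound 4 (0.22 log units; that floor lies within the scatter) is expected. This expectation rests on the step of a 3.2-fold lower number from compound 1 to compound 2 (0.51 log units; beyond the scatter), and on the starting value of compound 3 being only a limit. Compound 4 is therefore estimated at 60000 nM, expected to lie between 20000 nM and 200000 nM.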

Compound 4, half-maximal cytotoxic concentration: 100000 nM
For compound 4 the middle estimate is 1.7-fold (0.22 log units) below the measured one; the measured number falls inside the stated range.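

The swap of methyl for nitro gives a number no higher from compound 3 to compound 4 (the limit leaves the size open) in this assay and appears on two cores, and the two results compare as follows: the same change on two cores in this assay, a 3.2-fold lower number (0.51 log units; beyond the scatter) from compound 1 to compound 2 and a number no higher (the limit leaves the size open) from compound 3 to compound 4; the limit leaves it open whether they differ

In this assay compound 3 gives only a limit, > 100000 nM, so the size of the step to compound 4 cannot be read. The pair therefore shows that the number does not rise with this change on the core of compound 3, but it does not show whether the drop seen with a 3.2-fold lower number from compound 1 to compound 2 (0.51 log units; beyond the scatter) carries over to that core at the same size, or at all.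

The compounds shown carry only methyl or nitro at the changed place, so it stays open how an amine or a carboxylic acid there would read in this test. Also open, as far as these compounds go, is what the swap does when it sits at one and the same place on both cores, and how it reads from a starting compound with a measured number rather than a limit.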